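From a Fluorine to a Hindered Phenol on the Side Ring

This account rests on a few compounds, and the source may have more. Where it says the series, first, only, none or still open, it means among the compounds named here.

Of the compounds shown here, three sharing one core have been tested in a functional assay on KB cells (Homo sapiens) for antiproliferative activity, read by sulforhodamine B assay, with a stated time of 3 days; on this read-out higher numbers stand for an effect only at larger amounts of compound and lower numbers for an effect already at smaller amounts. Compound 1 `CCC1=C(O)c2c(oc(-c3ccc(C(C)C)cc3)cc2=O)C(CC)(CC)C1=O` gives 8.13 uM. Compound 2 `CCC1=C(O)c2c(oc(-c3ccc(COC)cc3)cc2=O)C(CC)(CC)C1=O` reaches only a limit of the assay, > 52.4 uM. Compound 3 `CCC1=C(O)c2c(oc(-c3ccccc3F)cc2=O)C(CC)(CC)C1=O` likewise reaches only a limit, > 56.2 uM. Thus compound 3 stands among the weaker entries, with an at least 6.9-fold higher number from compound 1 to compound 3 (0.83 log units; beyond the scatter), while a step that the two limits leave unreadable from compound 2 to compound 3. Compound 4 `CCC1=C(O)c2c(oc(-c3cc(C)c(O)c(C)c3)cc2=O)C(CC)(CC)C1=O` is not yet measured; its change is 4-hydroxy-3,5-dimethylphenyl in place of 2-fluorophenyl on an aromatic carbon. Among the measured compounds shown here, the only readable step from compound 3 runs back to compound 1, whose numbered result came with a substituted aromatic ring of similar bulk. Compound 4 is therefore expected to lie near 20 uM, within 5 uM to 70 uM. The estimated step is an at least 2.8-fold lower number from compound 3 to compound 4 (0.44 log units; beyond the scatter).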

Compound 4, concentration for half-maximal effect: 18.3 uM
Compound 4: the middle estimate sits 1.1-fold (0.04 log units) above what was measured, within the range that was stated.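

The 4-hydroxy-3,5-dimethylphenyl group shows that a side ring other than the 4-isopropylphenyl of compound 1 can give a measured number at this position in this assay, with an at least 3.0-fold lower number from compound 3 to compound 4 (0.48 log units; beyond the scatter) and an at least 2.8-fold lower number from compound 2 to compound 4 (0.45 log units; beyond the scatter). It does not match the 4-isopropylphenyl group, however, with a 2.3-fold higher number from compound 1 to compound 4 (0.35 log units; beyond the scatter). The result for compound 3 is a limit, not a number, so its step gives only a minimum size: the limit of > 56.2 uM in this assay, at which 1 of the 4 values shown sits.

Still open, on these data alone, is whether the hydroxyl or the two methyl groups account for the lower number. An amine or a carboxylic acid in place of the hydroxyl could help separate these two parts.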